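Swapping the aryl group on a fused nitrile core

The compounds below may be only part of what the source reports. "The series", "measured", "known", "first", "only" and "open" are said of these compounds alone.

Within the data shown here, compound 2 `COc1ccc(C2C(C#N)=C(N)N(c3ccc(S(N)(=O)=O)cc3)C3=C2C(=O)CCC3)c2ccccc12` is one of two compounds measured so far in a functional assay on Ehrlich cells (Mus musculus) for antiproliferative activity, read by trypan blue exclusion, with a stated time of 2 h, tested at 50 ug/mL; a lower number here means a weaker effect, a higher number a stronger effect of the compound at the concentration tested. In this assay compound 2 gives 30%, the lower of the two numbers. Compound 1 `N#CC1=C(N)N(c2ccc(S(N)(=O)=O)cc2)C2=C(C(=O)CCC2)C1c1ccc([N+](=O)[O-])cc1` gives 95% in this assay. Among the measured compounds shown here, the one change between them, 4-methoxynaphthalen-1-yl in place of 4-nitrophenyl on a saturated ring carbon, brought a number 65 percentage points lower from compound 1 to compound 2 (beyond the scatter). Compound 3 `N#CC1=C(N)N(c2ccc(S(N)(=O)=O)cc2)C2=C(C(=O)CCC2)C1c1cccs1` has not yet been measured. It differs from compound 2 in one place: thiophen-2-yl in place of 4-methoxynaphthalen-1-yl on a saturated ring carbon. For the measured compounds named here, only the step from compound 1 to compound 2 bears on this change; that step, too, exchanged the group on the same saturated ring carbon, and it was large. The group that arrived with the drop now leaves again, but thiophen-2-yl is not 4-nitrophenyl, so a full return to the higher number cannot be assumed. A rise in this assay beyond the scatter is expected for compound 3, on the order of a number 30 percentage points higher from compound 2 to compound 3 (beyond the scatter). Compound 3 is therefore estimated at 60% in this assay, within a range from 25% to 95%.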

Compound 3, a percentage reported as activity, at one concentration (the size of the read-out at that concentration, not a potency): 88%
Compound 3: the middle estimate sits 28 percentage points below what was measured; the range from low to high includes it.
By their numbers in this assay, from the lowest: compound 2; then compounds 3 and 1 (each within the scatter of the next).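

In this assay, replacing 4-methoxynaphthalen-1-yl with thiophen-2-yl on the saturated ring carbon gave a number 58 percentage points higher from compound 2 to compound 3 (beyond the scatter), so the high number is not tied to 4-nitrophenyl alone. Comparing the two high-reading groups directly gives a number 7 percentage points lower from compound 1 to compound 3 (within the scatter), which means this assay does not separate 4-nitrophenyl from thiophen-2-yl, even though the second is a five-membered aromatic ring with a sulfur atom. Of the three groups shown at this position, only 4-methoxynaphthalen-1-yl goes with the low number, but no measurement here explains why.

As far as these compounds go, how a plain naphthalen-1-yl or a 4-methoxyphenyl group would read on this carbon remains open, and with it whether the low number of compound 2 goes with the second aromatic ring, the methoxy group or only the two together. Also open, from the compounds shown here alone, is whether this carbon needs an aromatic ring at all, a question that a cyclohexyl group or a short alkyl chain there could address.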